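Swapping the pendant aryl ring on a shared core

A few compounds are considered here, and "the series" means these few. Any claim that something is new, unique, unknown or untested is made for them only; others in the source may bear on it.

Measured compounds:
- compound 1, `CCCS(=O)(=O)Nc1ccc(F)c(C(=O)c2n[nH]c3ncc(-c4cccc(F)c4)cc23)c1F`: 8.2%
- compound 2, `CCCS(=O)(=O)Nc1ccc(F)c(C(=O)c2n[nH]c3ncc(-c4ccc(OC)cc4)cc23)c1F`: 4.2%
- compound 3, `CCCS(=O)(=O)Nc1ccc(F)c(C(=O)c2n[nH]c3ncc(-c4ccc(OC)cc4Cl)cc23)c1F`: 5.3%

All three share one core and differ only in the aryl group attached to it. In an assay for binding affinity to dual specificity mitogen-activated protein kinase kinase 4 (Homo sapiens), read by KINOMEscan, tested at 100 nM (a higher number here means a weaker effect of the compound at the concentration tested, a lower number a stronger effect), compound 2 gives 4.2%, and the two neighbours lie close by: the step of a number 4 percentage points lower from compound 1 to compound 2 (within the scatter) and the step of a number 1.1 percentage points higher from compound 2 to compound 3 (within the scatter) both stay inside the scatter, as does a number 2.9 percentage points lower from compound 1 to compound 3 (within the scatter). Three different aryl groups therefore give numbers that cannot be told apart.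

Compound 4, `CCCS(=O)(=O)Nc1ccc(F)c(C(=O)c2n[nH]c3ncc(-c4cccc(C(F)(F)F)c4)cc23)c1F`, is not yet measured. It differs from compound 2 in one place: 3-(trifluoromethyl)phenyl in place of 4-methoxyphenyl on an aromatic carbon. This is again a swap of the pendant aryl group, the same kind of change as from compound 1 to compound 2 and from compound 1 to compound 3, which moved the numbers only within the scatter. The expected step of a number 2.8 percentage points higher from compound 2 to compound 4 (within the scatter) is therefore estimated to stay within the scatter too. Compound 4 is expected to give about 7% in this assay, with a range from 2% to 16%.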

Compound 4, a percentage reported as activity, at one concentration (the size of the read-out at that concentration, not a potency): 57%
Compound 4: middle estimate off by 50 percentage points, on the low side; measured number above the stated range.
By their numbers in this assay, from the lowest: compounds 2, 3 and 1 (each within the scatter of the next); then compound 4.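

Trifluoromethyl in place of fluoro on the pendant ring is enough to produce a number 48.8 percentage points higher from compound 1 to compound 4 (beyond the scatter) in this assay, so a change confined to one substituent can matter greatly here. The swaps of the whole aryl group give a number 52.8 percentage points higher from compound 2 to compound 4 (beyond the scatter) and a number 51.7 percentage points higher from compound 3 to compound 4 (beyond the scatter), which shows that this position does not accept every aryl group alike, although the first three compounds could not be told apart. Nothing measured here explains this weakening.

From the compounds shown here alone, it remains open how a methyl, chloro or nitrile group would read in the place of that trifluoromethyl. Going by these compounds, it is also open whether an amine or a carboxylic acid at that spot would bring the number back down to the level of compounds 1, 2 and 3.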